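The source may hold more compounds than are shown below. What is called first, only, known or untested is meant among the compounds shown, and "the series" means these compounds.

Working notes on the series. Compound 1 `O=C(O)Cc1sc(C(c2ccc(F)cc2)c2ccc(F)cc2)nc1-c1ccnc(N2CCCC2)c1` is measured in an in vitro functional assay on HEK285-7 cells for antagonist activity at prostaglandin D2 receptor 2 (Homo sapiens), read by BRET and beta-arrestin recruitment (a higher number here means a larger maximal response, a lower number a smaller maximal response), and gives 80%. Compound 2 `O=C(O)Cc1sc(C(c2ccccc2)c2ccc(F)cc2)nc1-c1ccc(Cl)cc1` gives 80% in this assay, so compound 1 stands level with compound 2 at the digits shown, the nearest neighbour in value, with no change beyond the scatter. Among the compounds with values here, no pair of measured compounds differs in a single place, so no step size at the aromatic carbon of the five-membered ring can be read off directly. Compound 3 `N#Cc1ccc(-c2nc(C(c3ccc(F)cc3)c3ccc(F)cc3)sc2CC(=O)O)cc1` is not yet measured. From compound 1 the change is 4-cyanophenyl in place of 2-(pyrrolidin-1-yl)pyridin-4-yl on an aromatic carbon. Compound 2, which carries 4-chlorophenyl at the corresponding place of the shared core, gives 80% in this assay, which is the only hint on how a plain aromatic group at that place behaves. The step of a number 2 percentage points lower from compound 1 to compound 3 (within the scatter) is therefore expected to be none beyond the scatter. For compound 3 the expected maximal response in this assay is 78%, with a range from 60% to 95%.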

Compound 3, largest response reached (reported as efficacy), in percent of the reference or control that the assay uses: 30%
Compound 3: middle estimate off by 48 percentage points, on the high side, outside the stated range (below it).
By their numbers in this assay, from the lowest: compound 3; then compounds 1 and 2 (each within the scatter of the next).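

In this assay, within the data shown here, the change to 4-cyanophenyl in place of 2-(pyrrolidin-1-yl)pyridin-4-yl on the aromatic carbon gives a number 50 percentage points lower from compound 1 to compound 3 (beyond the scatter) and is the first step that can be read at this position. It shows that the maximal response is sensitive to the group at this place with the rest of the core of compound 1 held fixed, while steps involving compound 2 cannot be read, as it differs from both other compounds in more than one place. Nothing at hand speaks to the reason for this step.

From the compounds shown here alone, the exchange replaces the ring nitrogen, the pyrrolidine and the nitrile in one move, so the part that carries the step stays open. Going by these compounds, whether unsubstituted pyridin-4-yl or 2-(morpholin-4-yl)pyridin-4-yl would stand with compound 1 or with compound 3 also remains open.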